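The source may report more compounds than this note shows. Statements on the series, on what has been measured and on what is new or still open speak of the compounds shown alone.

Working notes on the series. Compound 1 `CC(=O)NCCNC(=O)CCC(=O)Oc1c(C)c(C)c2c(c1C)CCC(C)(COc1ccc(/C=C3\SC(=O)NC3=O)cc1)O2` carries on the shared core a succinate ester whose chain ends in a (2-acetamidoethyl)carbamoyl group. In a functional assay on MDA-MB-231 cells (Homo sapiens) for antiproliferative activity, read by luminescence, with a stated time of 24 h (a lower number here means a stronger inhibitor, a higher number a weaker inhibitor), compound 1 gives > 25000 nM, which is a limit of the assay and not a number. Compound 2 `Cc1cc(C)c2c(c1C)OC(C)(COc1ccc(CC3SC(=O)NC3=O)cc1)CC2` differs from the rest in more than one place; in this assay compound 2 gives 12300 nM. Compound 3 `Cc1c(C)c2c(c(C)c1OC(=O)OC(C)(C)C)CCC(C)(COc1ccc(/C=C3\SC(=O)NC3=O)cc1)O2` carries tert-butoxy on the carbonyl carbon in place of the whole chain; in this assay compound 3 gives 3300 nM. Within the data shown here, the only measured step leaving compound 1 is an at least 7.5-fold lower number from compound 1 to compound 3 (0.87 log units; beyond the scatter), and because it rests on the limit of > 25000 nM in this assay, at which 1 of the 3 values shown sits, its true size is known only as a lower bound.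

Compound 4 `Cc1c(C)c2c(c(C)c1OC(=O)CCCC[C@@H]1SC[C@@H]3NC(=O)N[C@@H]31)CCC(C)(COc1ccc(/C=C3\SC(=O)NC3=O)cc1)O2` keeps the ester chain of compound 1 and changes its end: a group of 11 heavy atoms (7 carbon, 2 nitrogen, 1 oxygen, 1 sulfur; one five-membered non-aromatic ring with 1 hetero atom, one five-membered non-aromatic ring with 2 hetero atoms) in place of a group of 9 heavy atoms (5 carbon, 2 nitrogen, 2 oxygen; no ring), on a saturated chain carbon, two bonds along the chain from a carbonyl carbon. Among the measured compounds shown here, no measured step alters only this group; the step from compound 1 to compound 3 replaces the entire chain and so bears on compound 4 only loosely. The expected step is an at least 1.2-fold lower number from compound 1 to compound 4 (0.09 log units; that floor lies within the scatter), with little confidence in either direction. For compound 4 in this assay the estimate is 20000 nM, within 5000 nM to 80000 nM, and a limit rather than a number is a real possibility.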

Compound 4, half-maximal inhibitory concentration: 3500 nM
Compound 4: middle estimate off by 5.7-fold (0.76 log units), on the high side, outside the stated range (below it).
By their numbers in this assay, from the lowest: compounds 3 and 4 (each within the scatter of the next); then compound 2. At a limit, above all of these: compound 1.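

Changing only the end of the chain, on a saturated chain carbon, two bonds along the chain from a carbonyl carbon, gives in this assay an at least 7.1-fold lower number from compound 1 to compound 4 (0.85 log units; beyond the scatter); the ester chain stays, so this result isolates the end group, which the replacement of the entire chain in an at least 7.5-fold lower number from compound 1 to compound 3 (0.87 log units; beyond the scatter) could not do. Compound 3 gives 3300 nM and compound 4 gives 3500 nM, values within the scatter of each other, so the tert-butoxy group and the new ring-bearing chain end cannot be told apart in this read-out. The step from compound 1 to compound 4 is known only as a lower bound, because it rests on a limit and not on a number: the limit of > 25000 nM in this assay, at which 1 of the 4 values shown sits.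

On these data alone, it remains open whether the gain in compound 4 comes from the two five-membered rings and their 3 defined stereocentres, or simply from the loss of the (2-acetamidoethyl)carbamoyl group. A chain of the same length ending in a carboxylic acid or a primary amine would help separate these readings, and a value for compound 1 within the range of the assay would fix the size of both steps.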